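From piperidin-4-yl to piperidin-3-yl in compound 3

A few compounds are considered here, and "the series" means these few. Any claim that something is new, unique, unknown or untested is made for them only; others in the source may bear on it.

- Compound 1 `Cc1nc(C(NC(=O)C(=O)Nc2ccc(Cl)cc2)C2CCNCC2)sc1CCO`: 85400 nM
- Compound 2 `Cc1nc(C(NC(=O)C(=O)Nc2ccc(Cl)c(F)c2)C2CCCCN2)sc1CCO`: 61000 nM

Both numbers come from an ADME assay on TZM-b1 cells (Homo sapiens) for cytotoxicity, read by XTT assay, with a stated time of 3 days; on this read-out lower numbers stand for higher toxicity in this test and higher numbers for lower toxicity in this test. Compound 1 and compound 2 lie within the usual scatter of repeated measurements, so these two numbers cannot be ranked against each other. Among the compounds with values here, compound 1 therefore stands level with the only other measured compound. Within the data shown here, no measured pair here differs in just one place, so no single structural change has a measured effect to draw on.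

Compound 3 `Cc1nc(C(NC(=O)C(=O)Nc2ccc(Cl)cc2)C2CCCNC2)sc1CCO` has not yet been measured. It carries piperidin-3-yl in place of piperidin-4-yl on a saturated chain carbon bound to an amide-type nitrogen and an aromatic carbon. Compound 2 differs from the other measured compound in more than one place and still gives 61000 nM, so a step beyond the scatter is not expected in this assay, and no direction is expected either. The expected change is a 1.1-fold lower number from compound 1 to compound 3 (0.03 log units; within the scatter). For compound 3 the estimated value is 80000 nM, with an expected range from 38000 nM to 160000 nM.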

Compound 3, half-maximal cytotoxic concentration: 59400 nM
Beside the measured number, compound 3's estimate is 1.3-fold (0.13 log units) above it; low and high end bracket the measured number.
By their numbers in this assay, from the lowest: compounds 3, 2 and 1 (each within the scatter of the next).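

Within the data shown here, this is the first pair that differs in one place only, so the swap of the ring attachment can be read by itself. In this assay, putting piperidin-3-yl in place of piperidin-4-yl gives a 1.4-fold lower number from compound 1 to compound 3 (0.16 log units; within the scatter) and so cannot be counted as a real difference. On a saturated chain carbon bound to an amide-type nitrogen and an aromatic carbon, this test therefore does not tell these two piperidine groups apart, although they have the same atoms joined differently, and nothing available explains that result.

Still open, from the compounds shown here alone, is whether a group of another kind at this place, such as an open-chain amine or a carboxylic acid, would read level with the piperidine groups in this assay as well. Compound 2 differs from compound 1 in more than one place, so the effects of its ring attachment and its added fluorine cannot be separated.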